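This account rests on a few compounds, and the source may have more. Where it says the series, first, only, none or still open, it means among the compounds named here.

Compound 1 `COc1ccc(-c2cc(/C=C/C(=O)c3ccc(OC)c(OC)c3)[nH]n2)cc1`: 7810 nM
Compound 2 `COc1cc(-c2cc(/C=C/C(=O)c3ccc(Cl)c(Cl)c3)[nH]n2)cc(OC)c1OC`: > 100000 nM
Compound 3 `COc1ccc(-c2cc(/C=C/C(=O)c3ccc(N)cc3)[nH]n2)cc1OC`: 7240 nM

Compound 2 gives no number in a functional assay on HCC 2998 cells (Homo sapiens) for inhibition, read by sulforhodamine B assay, with a stated time of 48 h (on this read-out higher numbers stand for lower toxicity in this test and lower numbers for higher toxicity in this test), only (the limit of > 100000 nM in this assay, at which 1 of the 3 values shown sits). Compound 1 gives 7810 nM and compound 3 gives 7240 nM, both plain numbers. Compound 4 `COc1ccc(C(=O)/C=C/c2cc(-c3cc(OC)c(OC)c(OC)c3)n[nH]2)cc1OC` differs from compound 2 by 3,4-dimethoxyphenyl in place of 3,4-dichlorophenyl on a carbonyl carbon. Going by the values given here, no measured step links any two of the three measured compounds, so the expectation rests on the numbers alone. Since compound 1 and compound 3, whose aryl ketones carry methoxy or amino groups rather than chlorines, both give measurable toxicity, the step of an at least 12-fold lower number from compound 2 to compound 4 (1.09 log units; beyond the scatter) is expected to run towards higher toxicity, beyond the scatter. Compound 4 is therefore estimated at 8000 nM, with a range from 2500 nM to 40000 nM.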

Compound 4, concentration lethal to 50% of the cells: 6700 nM
Compound 4: middle estimate off by 1.2-fold (0.08 log units), on the high side, and the stated range covers the measured number.
By their numbers in this assay, from the lowest: compounds 4, 3 and 1 (each within the scatter of the next). At a limit, above all of these: compound 2.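

On a carbonyl carbon, 3,4-dimethoxyphenyl in place of 3,4-dichlorophenyl gives, in this assay, an at least 14-fold lower number from compound 2 to compound 4 (1.17 log units; beyond the scatter). This is the first single change shown at this position, and it separates the two groups beyond the scatter. The value of compound 2 is a limit, not a number: the limit of > 100000 nM in this assay, at which 1 of the 4 values shown sits.

The compounds shown leave open how a phenyl carrying a single chlorine, or a hydroxyphenyl, would read at this place in this assay. They also leave open whether the same change would give a similar step on the core of compound 1.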